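From phenyl to 2-fluorophenyl: an estimate for compound 4

The source may report more compounds than this note shows. Statements on the series, on what has been measured and on what is new or still open speak of the compounds shown alone.

compound 1 `CC(O)Cn1c([N+](=O)[O-])cnc1/C=C/c1ccccc1` gives 1500 nM
compound 2 `CC(O)Cn1c([N+](=O)[O-])cnc1/C=C/c1cccc(Cl)c1` gives 520 nM
compound 3 `CC(O)Cn1c([N+](=O)[O-])cnc1/C=C/c1cccc(Br)c1` gives 620 nM

In an ADME assay on cells (Macrophage, Homo sapiens) for cytotoxicity, read by MTT assay, with a stated time of 24 h (on this read-out higher numbers stand for lower toxicity in this test and lower numbers for higher toxicity in this test), compound 1 has the highest number of the three, so it is the least toxic to the cells. Compound 4 `CC(O)Cn1c([N+](=O)[O-])cnc1/C=C/c1ccccc1F` has not yet been measured. It differs from compound 1 by a single change fluoro in place of hydrogen on an aromatic carbon that puts fluoro in place of hydrogen on an aromatic carbon. Among the compounds with values here, two measured steps bear on this, and both are modest. Chloro gave a 2.9-fold lower number from compound 1 to compound 2 (0.46 log units; beyond the scatter) and bromo gave a 2.4-fold lower number from compound 1 to compound 3 (0.38 log units; beyond the scatter) on the same parent. The step of a 1.2-fold higher number from compound 2 to compound 3 (0.08 log units; within the scatter) shows that these two halogens can hardly be told apart. Both steps point downward, so a lower number is expected for fluoro too. Yet no fluoro compound has been measured, and this fluoro sits ortho to a large group, a place that neither compound 2 nor compound 3 fills. A smaller drop in this assay is therefore expected, with a 1.7-fold lower number from compound 1 to compound 4 (0.22 log units; within the scatter) as the estimated size. For compound 4 the expected value is 900 nM with an estimated range from 420 nM to 1900 nM in this test.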

Compound 4, half-maximal cytotoxic concentration: 1410 nM
The estimate for compound 4 lay 1.6-fold (0.19 log units) below the measured number, within the range that was stated.
By their numbers in this assay, from the lowest: compounds 2 and 3 (each within the scatter of the next); then compounds 4 and 1 (each within the scatter of the next).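

In this assay, putting fluoro on the ring ortho to a large group gives a number that cannot be told apart from that of the unsubstituted parent (a 1.1-fold lower number from compound 1 to compound 4 (0.03 log units; within the scatter)). So a halogen on this ring does not always go with a lower number, and compound 4 stands apart from both other halogen compounds (a 2.3-fold higher number from compound 3 to compound 4 (0.36 log units; beyond the scatter); a 2.7-fold higher number from compound 2 to compound 4 (0.43 log units; beyond the scatter)), although each of those two steps changes both the halogen and its place on the ring, so neither can separate the two changes. No measurement shown here accounts for this difference.

Still open, as far as these compounds go, is whether chloro or bromo in this same place would also stay level with compound 1, and whether fluoro in the place that compound 2 and compound 3 fill would match them. From the compounds shown here alone, how a methoxy group or an amine would read here is also open.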